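Reversing the Enone Arm: An Expectation for Compound 4

A few compounds are considered here, and "the series" means these few. Any claim that something is new, unique, unknown or untested is made for them only; others in the source may bear on it.

Compound 1 `COc1ccc(-c2cc(/C=C/C(=O)c3cc(OC)c(OC)c(OC)c3)nc3cc(-c4ccccc4)nn23)cc1OC` in an ADME assay on HEK293 cells (Homo sapiens) for antiproliferative activity, read by MTT assay, with a stated time of 24 h (on this read-out lower numbers stand for stronger inhibition and higher numbers for weaker inhibition), gives 35000 nM.
Compound 2 `COc1ccc(-c2cc(/C=C/C(=O)c3ccc(Cl)cc3)nc3cc(-c4ccccc4)nn23)cc1OC` gives 44100 nM.
Compound 3 `COc1cc(-c2cc(/C=C/C(=O)c3ccc(Cl)cc3)nc3cc(-c4ccccc4)nn23)cc(OC)c1OC` gives only a limit of the assay, >= 100000 nM.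

Among the two plain numbers, compound 2 has the higher one, yet a 1.3-fold higher number from compound 1 to compound 2 (0.10 log units; within the scatter) keeps it within the scatter of compound 1, so the two cannot be told apart. The third value sits at the limit of >= 100000 nM in this assay, at which 1 of the 3 values shown sits.

Compound 4 `COc1ccc(-c2cc(C(=O)/C=C/c3ccc(C)cc3)nc3cc(-c4ccccc4)nn23)cc1OC` has not been measured. It differs from compound 2 in one place: (2-(4-methylphenyl)ethenyl)carbonyl in place of 2-((4-chlorophenyl)carbonyl)ethenyl on an aromatic carbon. The two measured steps do not match this change. The step of a 1.3-fold higher number from compound 1 to compound 2 (0.10 log units; within the scatter) swapped the aryl group on the carbonyl carbon and did not move the number beyond the scatter. The step of an at least 2.2-fold higher number from compound 2 to compound 3 (0.35 log units; beyond the scatter) added a methoxy on an aromatic carbon and did move it, but toward weaker inhibition. Neither step reverses the order of carbonyl and double bond in the arm. Among the compounds with values here, with no directly comparable step, the expectation is that compound 4 behaves much like compound 2, with a 1.0-fold lower number from compound 2 to compound 4 (0.00 log units; within the scatter) expected to stay within the scatter. Compound 4 is therefore estimated at 44000 nM, in a range from 15000 nM to 130000 nM.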

Compound 4, half-maximal inhibitory concentration: 57400 nM
Beside the measured number, compound 4's estimate is 1.3-fold (0.12 log units) below it; measured number inside the range.
By their numbers in this assay, from the lowest: compounds 1, 2 and 4 (each within the scatter of the next). At a limit, above all of these: compound 3.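

In this assay, within the data shown here, the earlier steps changed the aryl group on the carbonyl carbon or added a methoxy on an aromatic carbon, but always left the arm running in the same direction; only this pair tests the reversed order of carbonyl and double bond. The result is a 1.3-fold higher number from compound 2 to compound 4 (0.11 log units; within the scatter), so on this aromatic carbon, next to the ring nitrogen, (2-(4-methylphenyl)ethenyl)carbonyl can take the place of 2-((4-chlorophenyl)carbonyl)ethenyl with no difference that can be told from the scatter. The data shown offer no explanation for this result.

This single swap both reverses the arm and replaces the chlorine on its aromatic ring with a methyl group, so the two changes cannot be separated, and a difference from one could be hidden by an opposite difference from the other. Also open, going by these compounds, is how the number would respond at this same position to a different kind of group, such as an amine or a carboxylic acid at the end of the arm, or a longer chain between the carbonyl and the aromatic ring.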